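A few compounds are considered here, and "the series" means these few. Any claim that something is new, unique, unknown or untested is made for them only; others in the source may bear on it.

Compound 3 `O=C(CC1c2ccccc2N=C(SCCCCCN2CCCC2)N1c1ccc(-c2ccc(F)cc2)cc1)NCc1ccccc1` was tested in an assay on cells for inhibition of Voltage-dependent T-type calcium channel subunit alpha-1I (Homo sapiens), read by patch clamp, tested at 10 uM (a lower number here means less inhibition, a higher number more inhibition at the concentration tested (going by the name of the read-out)), where compound 3 gives 68.2%. Two companions sit beside it. Compound 1 `O=C(CC1c2ccccc2N=C(SCCCCCN2CCCC2)N1c1ccc(-c2ccccc2)cc1)NCc1ccc(F)cc1` carries a fluoro on the benzyl amide instead of on the biphenyl, and in this assay compound 1 gives 55.9%, a number below that of compound 3 by more than the usual scatter. Compound 2 `CN(C)CCCCCSC1=Nc2ccccc2C(CC(=O)NCc2ccccc2)N1c1ccc(-c2ccccc2)cc1` carries a dimethylamino chain in place of the pyrrolidine chain, and in this assay compound 2 gives 85.6%, a number above that of compound 3 by more than the usual scatter. Compound 3 therefore stands second highest of the three, nearer to compound 1 than to compound 2.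

Compound 4 `O=C(CC1c2ccccc2N=C(SCCCCCN2CCCC2)N1c1ccc(-c2ccccc2)cc1)NCc1ccccc1` has not been measured. It differs from compound 3 by a single change: hydrogen in place of fluoro on an aromatic carbon. Among the measured compounds shown here, no pair among the measured compounds differs in this one place, so the size of the step has to be judged from the spread of the three numbers alone. As a single heavy atom leaves and nothing enters, the step from compound 3 to compound 4 is expected to be small, with no clear direction, and is estimated at a number 3.2 percentage points lower from compound 3 to compound 4 (within the scatter). In this assay compound 4 is expected to give about 65%, within a range from 45% to 85%.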

Compound 4, a percentage reported as inhibition, at one concentration (the size of the read-out at that concentration, not a potency): 92.7%
For compound 4 the middle estimate is 27.7 percentage points below the measured one; the measured number lies above the stated range.
By their numbers in this assay, from the lowest: compound 1; then compound 3; then compounds 2 and 4 (each within the scatter of the next).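

Compound 4 gives the three earlier compounds a common point of reference in this assay, with each now one change away from it. Going from 4-fluorophenyl to phenyl gives a number 24.5 percentage points higher from compound 3 to compound 4 (beyond the scatter), so this position is sensitive to a single fluoro, and removing the fluoro from the benzyl amide gives a number 36.8 percentage points higher from compound 1 to compound 4 (beyond the scatter), so among these compounds a fluoro at either place goes with less inhibition at the concentration tested. The amine behaves differently: exchanging dimethylamino for pyrrolidin-1-yl gives a number 7.1 percentage points higher from compound 2 to compound 4 (within the scatter), so these two chain ends are not told apart here.

Nothing available here explains why either fluoro goes with a lower number. As far as these compounds go, whether this drop is particular to fluoro or would follow any group at these places remains open, and a chloro or methoxy on the phenyl, or a piperidine at the end of the chain or a shorter chain between the sulfur and the amine, would help to show how far these trends extend.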